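Replacing nitro by amino on a styryl benzyl sulfone

This account rests on a few compounds, and the source may have more. Where it says the series, first, only, none or still open, it means among the compounds named here.

Compound 3 `COc1ccc(CS(=O)(=O)/C=C/c2ccc([N+](=O)[O-])cc2)cc1` is tested in a functional assay on DLD-1 cells (Homo sapiens) for antiproliferative activity, read by trypan blue exclusion (on this read-out lower numbers stand for stronger inhibition and higher numbers for weaker inhibition), where compound 3 gives 5000 nM. Among the numbers shown, compound 3 sits highest; compound 2 `COc1ccc(CS(=O)(=O)/C=C/c2ccc(F)cc2)cc1` gives 2000 nM, and the step of a 2.5-fold higher number from compound 2 to compound 3 (0.40 log units; beyond the scatter) lies beyond the scatter. Compound 1 `COc1ccc(/C=C/S(=O)(=O)Cc2ccc(OC)cc2)cc1` reaches only the assay limit of > 20000 nM. Compound 4 `COc1ccc(CS(=O)(=O)/C=C/c2ccc(N)cc2)cc1` differs from compound 3 by amino in place of nitro on an aromatic carbon. Within the data shown here, no measured step swaps nitro for amino; the steps of an at least 10-fold lower number from compound 1 to compound 2 (1.00 log units; beyond the scatter) and an at least 4.0-fold lower number from compound 1 to compound 3 (0.60 log units; beyond the scatter) show only that this aromatic group shifts the number modestly. A modest step in either direction is therefore expected for compound 4, estimated at 2500 nM, between 600 nM and 10000 nM, which is expected to mean a 2.0-fold lower number from compound 3 to compound 4 (0.30 log units; within the scatter).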

Compound 4, half-maximal inhibitory concentration: > 20000 nM
Compound 4 was reported as a limit; the forecaster's own chance of this, stated with the estimate: 10%; at least 8.0-fold (0.90 log units) between middle value and limit.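

In this assay, the new group costs activity against both earlier compounds: an at least 4.0-fold higher number from compound 3 to compound 4 (0.60 log units; beyond the scatter), and an at least 10-fold higher number from compound 2 to compound 4 (1.00 log units; beyond the scatter). Among these compounds, this aromatic position therefore separates amino from nitro and fluoro, whereas the earlier compounds showed only a modest gap between those last two groups. The step between compound 1 and compound 4 cannot be read because both are reported only as a limit: the limit of > 20000 nM in this assay, at which 2 of the 4 values shown sit.

As far as these compounds go, how an acetamide or a dimethylamino group would behave at this position remains open. So does the true value of compound 4, which lies somewhere beyond its limit.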